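Piperazine Substituent Swap in a Dithiocarbamate Benzamide Series

The source may report more compounds than this note shows. Statements on the series, on what has been measured and on what is new or still open speak of the compounds shown alone.

Measured compounds:
- compound 1, `COc1ccc(N2CCN(C(=S)SCc3ccc(C(=O)Nc4ccccc4N)cc3)CC2)cc1`: 35.9%
- compound 2, `Nc1ccccc1NC(=O)c1ccc(CSC(=S)N(Cc2ccccc2)Cc2ccccc2)cc1`: 32.5%
- compound 3, `Nc1ccccc1NC(=O)c1ccc(CSC(=S)N2CCCC2)cc1`: 89.5%

These three compounds were tested in a functional assay on A-375 cells (Homo sapiens) for antiproliferative activity, read by CCK-8 assay, with a stated time of 72 h, tested at 8 uM; a higher number here means a stronger effect of the compound at the concentration tested, a lower number a weaker effect. Compound 1 gives 35.9%, the second highest of the three numbers. Its nearest neighbour is compound 2, whose 32.5% lies within the usual scatter of compound 1, so the two cannot be told apart. Compound 3, with 89.5%, sits well beyond the scatter above compound 1.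

The next compound, compound 4, is `Nc1ccccc1NC(=O)c1ccc(CSC(=S)N2CCN(Cc3cccnc3)CC2)cc1`. It differs from compound 1 in one place: (pyridin-3-yl)methyl in place of 4-methoxyphenyl on an amine nitrogen in a ring. The ring on the amine nitrogen thus loses its 4-methoxyphenyl and gains a (pyridin-3-yl)methyl instead.

Among the measured compounds shown here, no measured pair shows the effect of this exact change, so the expectation rests only on the spread of the three values shown. The step from compound 1 to compound 4 is expected to be small, a number 9.1 percentage points higher from compound 1 to compound 4 (within the scatter), in the upward direction but possibly within the scatter. Compound 4 is therefore estimated at 45%, with a range from 25% to 72%.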

Compound 4, a percentage reported as inhibition, at one concentration (the size of the read-out at that concentration, not a potency): 89.2%
Compound 4: middle estimate off by 44.2 percentage points, on the low side; measured number above the stated range.
By their numbers in this assay, from the lowest: compounds 2 and 1 (each within the scatter of the next); then compounds 4 and 3 (each within the scatter of the next).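

In this assay the swap of 4-methoxyphenyl for (pyridin-3-yl)methyl on an amine nitrogen in a ring gives a number 53.3 percentage points higher from compound 1 to compound 4 (beyond the scatter) as a large step. This shows that the group at this position can separate a weak effect from a strong one at the tested concentration, even though the two groups match in hydrogen-bond donors and acceptors and each holds a six-membered aromatic ring. Nothing available speaks to the reason for this step.

The swap changes several things at once: the methoxy group goes, a nitrogen enters the aromatic ring, and a carbon link appears between the two rings. Which of these matters remains open, and a plain benzyl or a 4-methoxybenzyl group on the same nitrogen would help to separate them.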